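Swapping the amide aryl group for a furanylmethyl chain

The source may report more compounds than this note shows. Statements on the series, on what has been measured and on what is new or still open speak of the compounds shown alone.

Compound 1 `COCOc1cc(/C=C/C(=O)OCC(=O)Nc2ccc(OC)cc2)ccc1OCc1ccccc1` was tested in a functional assay on ECa-109 cells (Homo sapiens) for cytotoxicity, read by MTT assay, with a stated time of 72 h; a higher number here means a weaker inhibitor, a lower number a stronger inhibitor. In this assay compound 1 gives only a limit, > 200000 nM, so no number is known for it. Compound 2 `COc1ccc(NC(=O)COC(=O)/C=C/c2ccc(OCc3ccccc3)c(O)c2)cc1` likewise gives only a limit in this assay, > 200000 nM. For the measured compounds named here, compound 3 `COc1ccc(NC(=O)COC(=O)/C=C/c2ccc(O)c(O)c2)cc1` gives 190000 nM in this assay, the one measured number among the three. The step that the two limits leave unreadable from compound 1 to compound 2 cannot be read, and the step of an at least 1.0-fold lower number from compound 2 to compound 3 (0.02 log units; that floor lies within the scatter) is within the scatter. Two of the three values sit at the limit of > 200000 nM in this assay, at which 2 of the 3 values shown sit, and compound 1 is one of them, so it stands at the edge of what this assay reports.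

Compound 4 `COCOc1cc(/C=C/C(=O)OCC(=O)NCc2ccco2)ccc1OCc1ccccc1` has not yet been measured. It differs from compound 1 by (furan-2-yl)methyl in place of 4-methoxyphenyl on an amide-type nitrogen. Neither measured step touches the amide nitrogen: the step from compound 1 to compound 2 and the step from compound 2 to compound 3 change oxygens on the aromatic ring, and all three measured compounds carry the same 4-methoxyphenyl on that nitrogen. Going by the values given here, no measured step therefore bears directly on this change. With every measured compound at or close to the limit of this assay, compound 4 is expected to stay near that limit as well, and the step of a number no higher from compound 1 to compound 4 (the limit leaves the size open) is expected to be within the scatter. The estimated value for compound 4 in this assay is 200000 nM, with a range from 80000 nM to 500000 nM, and it will most likely again be reported only as a limit.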

Compound 4, half-maximal inhibitory concentration: > 200000 nM
Compound 4: no number, only a limit; the forecaster's own chance of this, stated with the estimate: 70%; the middle value lies on the limit itself.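

In this assay compound 4 gives only a limit, > 200000 nM. For the compounds shown here, compound 1 also gives only a limit, so no step from compound 1 to compound 4 can be read. The compounds shown leave open whether (furan-2-yl)methyl in place of 4-methoxyphenyl on the amide-type nitrogen changes the value at all, with most results resting at one edge: the limit of > 200000 nM in this assay, at which 3 of the 4 values shown sit.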